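The compounds below may be only part of what the source reports. "The series", "measured", "known", "first", "only" and "open" are said of these compounds alone.

Measured compounds:
- compound 1 `COc1cccc(/C=C2\CCC/C(=C\c3ccccc3Cl)C2=O)c1OC`: 10300 nM
- compound 3 `COc1cccc(/C=C2\CCC/C(=C\c3ccc(Cl)cc3Cl)C2=O)c1OC`: 16300 nM
- compound 2 `COc1cccc(/C=C2\CCC/C(=C\c3ccc(O)cc3)C2=O)c1OC`: > 20000 nM, a limit of the assay the limit of > 20000 nM in this assay, at which 1 of the 3 values shown sits.

All three share one core and differ only in the aryl group on a double-bonded chain carbon bound to a double-bonded ring carbon. In a functional assay on SW-620 cells (Homo sapiens) for cytotoxicity, read by MTT assay, with a stated time of 72 h (a higher number here means a weaker inhibitor, a lower number a stronger inhibitor), compound 1 stands lowest of the two plain numbers, and the gap to compound 3 is a 1.6-fold higher number from compound 1 to compound 3 (0.20 log units; within the scatter). Compound 4 `COc1cccc(/C=C2\CCC/C(=C\c3ccc(Cl)c(Cl)c3)C2=O)c1OC` is the next step from compound 1: 3,4-dichlorophenyl in place of 2-chlorophenyl on a double-bonded chain carbon bound to a double-bonded ring carbon. The one comparable move, a second chloro on the ring, gave a 1.6-fold higher number from compound 1 to compound 3 (0.20 log units; within the scatter), so the change to compound 4 is expected to stay within the scatter, a 1.3-fold higher number from compound 1 to compound 4 (0.10 log units; within the scatter). Compound 4 is therefore estimated at 13000 nM, with a range from 6000 nM to 28000 nM.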

Compound 4, half-maximal inhibitory concentration: 10000 nM
Beside the measured number, compound 4's estimate is 1.3-fold (0.11 log units) above it, and the stated range covers the measured number.
By their numbers in this assay, from the lowest: compounds 4, 1 and 3 (each within the scatter of the next). At a limit, above all of these: compound 2.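

In this assay, replacing 2-chlorophenyl with 3,4-dichlorophenyl gives a 1.0-fold lower number from compound 1 to compound 4 (0.01 log units; within the scatter), and replacing 2,4-dichlorophenyl with 3,4-dichlorophenyl gives a 1.6-fold lower number from compound 3 to compound 4 (0.21 log units; within the scatter). The number and placement of chloro groups on this aryl ring therefore do not separate compound 1, compound 3 and compound 4. The step of an at least 2.0-fold lower number from compound 2 to compound 4 (0.30 log units; that floor lies within the scatter) can be read only as a floor, because compound 2 stands at a limit of the assay: the limit of > 20000 nM in this assay, at which 1 of the 4 values shown sits.

On these data alone, whether an amine or a carboxylic acid on this aryl ring would shift the number beyond the scatter remains open.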